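Iodo to methyl: working notes on a small series

The source may report more compounds than this note shows. Statements on the series, on what has been measured and on what is new or still open speak of the compounds shown alone.

Measured so far in a functional assay on L1210 cells (Mus musculus) for antiproliferative activity, with a stated time of 48 h; a lower number here means a stronger inhibitor, a higher number a weaker inhibitor (two compounds):
- Compound 1 `C=C(Br)C(=O)Nc1ccc(/C=C/C(=O)c2ccc(Cl)c(Cl)c2)cc1` gives 2100 nM
- Compound 2 `C=C(Br)C(=O)Nc1ccc(/C=C/C(=O)c2ccc(I)cc2)cc1` gives 3400 nM

Compound 2 lies within the scatter of compound 1, so these two values set no order. The next structure is compound 3 `C=C(Br)C(=O)Nc1ccc(/C=C/C(=O)c2ccc(C)cc2)cc1` and the change from compound 2 is methyl in place of iodo on an aromatic carbon. Among the measured compounds shown here, no measured step covers this exact swap. For the measured compounds named here, the one step that bears on it is a 1.6-fold higher number from compound 1 to compound 2 (0.21 log units; within the scatter) (4-iodophenyl in place of 3,4-dichlorophenyl on a carbonyl carbon) and it stays within the scatter. On this thin evidence, no step beyond the scatter is expected in this assay and no direction can be assigned. The estimated step is a 1.1-fold lower number from compound 2 to compound 3 (0.05 log units; within the scatter) and it is expected to stay within the scatter. Compound 3 is estimated at 3000 nM (expected range 1300 nM to 7000 nM) pending measurement.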

Compound 3, half-maximal inhibitory concentration: 1900 nM
Beside the measured number, compound 3's estimate is 1.6-fold (0.20 log units) above it; measured number inside the range.
By their numbers in this assay, from the lowest: compounds 3, 1 and 2 (each within the scatter of the next).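

In this assay, methyl in place of iodo, para to a large group on the six-membered aromatic ring, gives a 1.8-fold lower number from compound 2 to compound 3 (0.25 log units; within the scatter), so this swap produces no readable change at this position. The comparison with the dichloro compound reads the same: 4-methylphenyl in place of 3,4-dichlorophenyl gives a 1.1-fold lower number from compound 1 to compound 3 (0.04 log units; within the scatter), so among these three compounds a halogen on this ring is not required for a value in this range. Nothing available explains this flat reading.

On these data alone, whether an amine, a carboxylic acid or a longer chain at this position would move the number beyond the scatter remains open. Also open is what a change elsewhere on the shared core would do in this assay, as every compound shown keeps that core unchanged.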